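The compounds below may be only part of what the source reports. "The series", "measured", "known", "first", "only" and "open" are said of these compounds alone.

Compound 3 `Nc1ccc(-c2nnn(Cc3ccc(C(=O)NO)cc3)n2)cc1` carries a hydroxamic acid group, as do compound 1 `Cc1cc(-c2nnc(Sc3c(F)cc(C(=O)NO)cc3F)n2C)nn1C` and compound 2 `Cn1c(Sc2c(F)cc(C(=O)NO)cc2F)nnc1-c1ncccc1F`. In an assay on Sf9 cells for inhibition of protein deacetylase HDAC6 (Homo sapiens), read by fluorescence (on this read-out lower numbers stand for stronger inhibition and higher numbers for weaker inhibition), compound 3 gives 1 nM, the lowest number of the three; compound 1 gives 6 nM and compound 2 gives 6 nM, each beyond the scatter from compound 3. Going by the values given here, the only measured step, no change at the digits printed from compound 1 to compound 2 (within the scatter), concerns a different core and a different place, so it says little about the change now in question.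

Compound 4 `O=C(NO)c1ccc(Cn2nnc(Cc3ccccn3)n2)cc1` is not yet measured. It differs from compound 3 in one place: (pyridin-2-yl)methyl in place of 4-aminophenyl on an aromatic carbon. The change sits on an aromatic carbon of a five-membered aromatic ring with 4 nitrogen, and the group is now joined through a one-carbon link instead of directly. Among the compounds with values here, no measured pair shows this kind of change, so the direction is uncertain; a modest loss of potency is expected, with a 4.0-fold higher number from compound 3 to compound 4 (0.60 log units; beyond the scatter). Compound 4 is therefore estimated at 4 nM, in a range from 1 nM to 20 nM.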

Compound 4, half-maximal inhibitory concentration: 25 nM
For compound 4 the middle estimate is 6.3-fold (0.80 log units) below the measured one; measured number above the stated range.
By their numbers in this assay, from the lowest: compound 3; then compounds 1 and 2 (each within the scatter of the next); then compound 4.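

In this assay, the group on an aromatic carbon of the five-membered aromatic ring with 4 nitrogen clearly matters: replacing 4-aminophenyl with (pyridin-2-yl)methyl gives a 25-fold higher number from compound 3 to compound 4 (1.40 log units; beyond the scatter), a large step. The two groups have the same count of heavy atoms, so heavy-atom count alone does not set the number at this place. Several features change together, namely the one-carbon link, the ring nitrogen and the loss of the hydrogen-bond donor, and no evidence bears on which of them accounts for the step.

A 4-aminobenzyl group would keep the 4-aminophenyl ring but add the one-carbon link, while pyridin-2-yl joined directly would keep the ring of compound 4 without that link. Neither is among the compounds shown, so the contributions of the link and the ring remain open.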